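Swapping the aryl group on the triazole of a bicyclic lactam

The source may report more compounds than this note shows. Statements on the series, on what has been measured and on what is new or still open speak of the compounds shown alone.

Measured compounds:
Compound 1, `CC1(C)[C@H]2CC[C@]1(C)N(Cc1cn(-c3ccc(Cl)cc3)nn1)C(=O)C2`: 70 nM
Compound 2, `CC1(C)[C@H]2CC[C@]1(C)N(Cc1cn(-c3cccc(O)c3)nn1)C(=O)C2`: 180 nM

Both compounds share a bicyclic lactam core linked to a triazole that carries an aromatic ring. In a functional assay on A549 cells (Homo sapiens) for inhibition, read by MTT assay, with a stated time of 24 h (a lower number here means a stronger inhibitor, a higher number a weaker inhibitor), compound 1 gives 70 nM and compound 2 gives 180 nM. Among the compounds with values here, compound 2 therefore stands at the high end of the two numbers, a weaker inhibitor than its only neighbour, with a 2.6-fold higher number from compound 1 to compound 2 (0.41 log units; beyond the scatter).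

Compound 3, `CC1(C)[C@H]2CC[C@]1(C)N(Cc1cn(-c3ccc(C#N)cc3)nn1)C(=O)C2`, has not yet been measured. Its change from compound 2 is 4-cyanophenyl in place of 3-hydroxyphenyl on an aromatic nitrogen. Within the data shown here, the only step that bears on it is the one from compound 1 to compound 2, which also exchanged the aromatic ring on the triazole nitrogen and cost a modest amount of potency. Compound 3 returns to an aromatic ring substituted in the same pattern as the 4-chlorophenyl of compound 1, though with a nitrile rather than a chlorine, a swap for which no measurement exists. Compound 3 is therefore expected to recover most of that loss, with a 2.0-fold lower number from compound 2 to compound 3 (0.30 log units; within the scatter) in this assay. The estimate for compound 3 is 90 nM, within a range from 40 nM to 250 nM.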

Compound 3, half-maximal inhibitory concentration: 140 nM
For compound 3 the middle estimate is 1.6-fold (0.19 log units) below the measured one, within the range that was stated.
By their numbers in this assay, from the lowest: compounds 1, 3 and 2 (each within the scatter of the next, the first and the last beyond it).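

In this assay, the step shows a 1.3-fold lower number from compound 2 to compound 3 (0.11 log units; within the scatter), so 4-cyanophenyl on the aromatic nitrogen cannot be told apart from 3-hydroxyphenyl, even though the hydrogen-bond donor of the 3-hydroxyphenyl group is gone. The other new step, the first here in which only the group on the aromatic carbon changes, shows a 2.0-fold higher number from compound 1 to compound 3 (0.30 log units; within the scatter), so cyano in place of chloro also stays inside the usual spread of repeated measurements, and compound 3 cannot be separated from either neighbour, although compound 1 and compound 2 do stand apart from each other. Nothing measured here explains why these aryl groups give such similar numbers.

The hydroxyl and the nitrile differ both in what they are and in where they sit on the ring, so these compounds cannot show which of the two matters for the gap between compound 2 and compound 3. On these data alone, it also remains open what a plain phenyl ring, or an aryl ring bearing an amine or a carboxylic acid, would give at this triazole nitrogen.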